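Swapping phenoxy for dimethylamino: what to expect

The source may report more compounds than this note shows. Statements on the series, on what has been measured and on what is new or still open speak of the compounds shown alone.

Measured so far:
compound 1 `COc1cc(C)cc(-c2c(-c3ccnc(-c4ccc(C(C)=O)cc4)c3)cnn2CC#N)c1`: -4%
compound 2 `COc1cc(C)cc(-c2nn(CC#N)cc2-c2ccc(-c3cccc(C(C)=O)c3)nc2)c1`: 8%
compound 3 `Cc1cc(O)cc(-c2nn(CC#N)cc2-c2ccnc(-c3ccc(Oc4ccccc4)cc3)c2)c1`: -20%

All three compounds were tested in a functional assay on RPMI8266 cells (Homo sapiens) for cytotoxicity, read by sulforhodamine B assay, with a stated time of 48 h, tested at 1 uM; a higher number here means a weaker effect of the compound at the concentration tested, a lower number a stronger effect. Compound 3 gives the lowest of the three numbers: compound 1 lies higher by a margin beyond the scatter, and compound 2 lies higher still, also beyond it, so compound 3 shows the strongest effect of the three.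

Compound 4 `Cc1cc(O)cc(-c2nn(CC#N)cc2-c2ccnc(-c3ccc(N(C)C)cc3)c2)c1` has not yet been measured. It differs from compound 3 by dimethylamino in place of phenoxy on an aromatic carbon. For the measured compounds named here, no measured pair shows what such a swap does, so the size of the step in this assay is uncertain; a change of no more than the usual scatter, in either direction, seems the most likely outcome. Compound 4 is therefore expected to give -10%, with a range from -30% to 15%. This estimate means an expected step of a number 10 percentage points higher from compound 3 to compound 4 (within the scatter).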

Compound 4, a percentage reported as activity, at one concentration (the size of the read-out at that concentration, not a potency): 15%
Beside the measured number, compound 4's estimate is 25 percentage points below it; low and high end bracket the measured number.
By their numbers in this assay, from the lowest: compound 3; then compound 1; then compounds 2 and 4 (each within the scatter of the next).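

In this assay, dimethylamino in place of phenoxy gives a number 35 percentage points higher from compound 3 to compound 4 (beyond the scatter), the first measured sign that the group on this aromatic carbon affects the read-out. The swap removes a six-membered aromatic ring of carbon only, while the hydrogen-bond donor and acceptor counts stay the same. No measurement here explains the step.

On these data alone, it remains open whether the aromatic ring itself matters or whether the nitrogen of the entering group does. A cyclohexyloxy group or a piperidine at this place could help separate the two.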